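Alkyne substituent changes in the series

A few compounds are considered here, and "the series" means these few. Any claim that something is new, unique, unknown or untested is made for them only; others in the source may bear on it.

Compound 1 `CCCCC#Cc1cn(C/C=C\CN2C(=O)c3ccccc3C2=O)c(=O)[nH]c1=O` carries a hexynyl arm and in a functional assay on HepG2 cells (Homo sapiens) for antiproliferative activity, read by MTT assay, with a stated time of 3 days (a lower number here means a stronger inhibitor, a higher number a weaker inhibitor), compound 1 gives 17000 nM. Compound 2 `O=C1c2ccccc2C(=O)N1C/C=C\Cn1cc(C#CCCc2ccccc2)c(=O)[nH]c1=O` is its closest analogue in the set. In this assay compound 2 reaches only a limit, > 100000 nM. The change between them cost an at least 5.8-fold higher number from compound 1 to compound 2 (0.76 log units; beyond the scatter), a figure bounded by the limit of > 100000 nM in this assay, at which 1 of the 2 values shown sits. Compound 3 `CCCCc1ccc(C#Cc2cn(C/C=C\CN3C(=O)c4ccccc4C3=O)c(=O)[nH]c2=O)cc1` follows: 4-butylphenyl in place of phenethyl on a triple-bonded carbon, so the aromatic ring now sits on the triple bond itself and carries a butyl chain. Among the compounds with values here, no measured step matches this change; the only one available, the weakening from compound 1 to compound 2, went toward weaker inhibition when an aromatic ring was introduced, but says nothing about an aryl alkyne. The step from compound 2 to compound 3 is therefore expected to be an at least 2.5-fold lower number from compound 2 to compound 3 (0.39 log units; beyond the scatter), with wide uncertainty and a real chance of another limit. Compound 3 is estimated at 40000 nM (range 8000 nM to 200000 nM).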

Compound 3, half-maximal inhibitory concentration: 40000 nM
The estimate for compound 3 equals the measured number at the digits printed; low and high end bracket the measured number.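

With 4-butylphenyl in place of phenethyl on a triple-bonded carbon, the series returns to a measurable value in this assay, with an at least 2.5-fold lower number from compound 2 to compound 3 (0.39 log units; beyond the scatter). The size of that step is bounded rather than exact, and compound 2 stands at a limit: the limit of > 100000 nM in this assay, at which 1 of the 3 values shown sits.
Set against butyl on the same carbon, 4-butylphenyl still gives a 2.4-fold higher number from compound 1 to compound 3 (0.37 log units; beyond the scatter), so among these three compounds an aromatic ring on the triple-bonded carbon reads better than phenethyl, yet neither arm matches butyl.

The compounds shown leave open how much of the recovery belongs to the ring and how much to its butyl chain; plain phenyl on the triple-bonded carbon would separate the two. Also open, on these data alone, is how an arm carrying an amine or a carboxylic acid, or a longer chain in place of butyl, would read in this assay.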